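Compound 4: Hydroxy and Methoxy Exchanged on the Chain-End Phenyl

This account rests on a few compounds, and the source may have more. Where it says the series, first, only, none or still open, it means among the compounds named here.

Measured compounds:
compound 1, `COc1ccc(-c2cn(-c3cccc(C(=O)/C=C/c4ccc(O)c(OC)c4)c3)nn2)cc1`: 7900 nM
compound 2, `COc1cc(/C=C/C(=O)c2cccc(-n3cc(-c4ccccc4C(F)(F)F)nn3)c2)ccc1O`: 5070 nM
compound 3, `COc1cc(/C=C/C(=O)c2cccc(-n3cc(-c4ccc(Br)cc4)nn3)c2)ccc1O`: 19100 nM

Of the compounds shown here, three have been measured in a functional assay on RAW264.7 cells (Mus musculus) for inhibition, with a stated time of 4 days; on this read-out lower numbers stand for stronger inhibition and higher numbers for weaker inhibition. Compound 1 stands second highest of the three numbers. Its nearest neighbour is compound 2, with a 1.6-fold lower number from compound 1 to compound 2 (0.19 log units; within the scatter), a step that lies within the scatter, so the two cannot be ordered. Its furthest neighbour is compound 3, with a 2.4-fold higher number from compound 1 to compound 3 (0.38 log units; beyond the scatter), a modest step beyond the scatter. Between the other two, a 3.8-fold higher number from compound 2 to compound 3 (0.58 log units; beyond the scatter) is also modest and beyond the scatter.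

Compound 4, `COc1ccc(-c2cn(-c3cccc(C(=O)/C=C/c4ccc(OC)c(O)c4)c3)nn2)cc1`, has not yet been measured. It differs from compound 1 only in the phenyl at the end of the chain: 3-hydroxy-4-methoxyphenyl in place of 4-hydroxy-3-methoxyphenyl on a double-bonded chain carbon bound to a double-bonded chain carbon. All three measured steps concern the aryl group attached to the triazole ring of the shared core; none of them touches the group on the double-bonded chain carbon, and none rearranges hydroxy and methoxy on any ring. Within the data shown here, no measured step therefore bears on this change, and the account can only state that directly.

With nothing to lean on, the expectation for compound 4 is a step of no meaningful size in this assay, a 1.0-fold higher number from compound 1 to compound 4 (0.01 log units; within the scatter), in no preferred direction. Compound 4 is estimated at 8000 nM, with a range from 3000 nM to 22000 nM.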

Compound 4, half-maximal inhibitory concentration: 6290 nM
The estimate for compound 4 lay 1.3-fold (0.10 log units) above the measured number; the range from low to high includes it.
By their numbers in this assay, from the lowest: compounds 2, 4 and 1 (each within the scatter of the next); then compound 3.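

In this assay, the exchange of hydroxy and methoxy on the chain-end phenyl gives a 1.3-fold lower number from compound 1 to compound 4 (0.10 log units; within the scatter), so 3-hydroxy-4-methoxyphenyl and 4-hydroxy-3-methoxyphenyl cannot be told apart on a double-bonded chain carbon bound to a double-bonded chain carbon. Among these compounds, this is the first reading at this position, as the earlier steps changed only 4-methoxyphenyl, 2-(trifluoromethyl)phenyl and 4-bromophenyl elsewhere on the shared core, and one of those, a 2.4-fold higher number from compound 1 to compound 3 (0.38 log units; beyond the scatter), lies beyond the scatter, unlike the exchange here. No supporting measurement bears on why the two arrangements read alike.

Whether the exchange would read the same way alongside the 2-(trifluoromethyl)phenyl of compound 2 or the 4-bromophenyl of compound 3 remains open, since the only pair shown carries 4-methoxyphenyl. Also open, on these data alone, is whether the chain-end phenyl needs its hydroxy and methoxy at all: these compounds do not show what an amine or a carboxylic acid in place of the hydroxy, or an ethoxy in place of the methoxy, would do to the number in this assay.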